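The compounds below may be only part of what the source reports. "The series", "measured", "known", "first", "only" and "open" are said of these compounds alone.

Compound 2 `Nc1ncnc2c1nc(NCc1cccc(Cl)c1)n2[C@@H]1O[C@H](CO)[C@@H](O)[C@H]1O` gives the lower of the two numbers in an assay on COS-7 cells for inhibition of sodium/nucleoside cotransporter 2 (Homo sapiens), read by scintillation counting, in the presence of a further agent that is not named here (on this read-out higher numbers stand for weaker inhibition and lower numbers for stronger inhibition), at 5400 nM, while compound 1 `Cc1ccccc1CNc1nc2c(N)ncnc2n1[C@@H]1O[C@H](CO)[C@@H](O)[C@H]1O` gives 65000 nM. Among the compounds with values here, the only measured step, a 12-fold lower number from compound 1 to compound 2 (1.08 log units; beyond the scatter), changes both the group and where it sits. Compound 3 `Nc1ncnc2c1nc(NCc1ccccc1Cl)n2[C@@H]1O[C@H](CO)[C@@H](O)[C@H]1O` differs from compound 2 by 2-chlorophenyl in place of 3-chlorophenyl on a saturated chain carbon bound to a nitrogen on an aromatic ring. Within the data shown here, no measured step isolates this change, but compound 1, which bears a 2-methylphenyl at the same place, gave the higher number of 65000 nM, so a weaker result is expected. The expected step is a 3.7-fold higher number from compound 2 to compound 3 (0.57 log units; beyond the scatter). Compound 3 is therefore estimated at 20000 nM, within 6000 nM to 65000 nM.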

Compound 3, half-maximal inhibitory concentration: 5700 nM
Compound 3: middle estimate off by 3.5-fold (0.55 log units), on the high side; the whole stated range lies above it.
By their numbers in this assay, from the lowest: compounds 2 and 3 (each within the scatter of the next); then compound 1.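

Exchanging 3-chlorophenyl for 2-chlorophenyl on a saturated chain carbon bound to a nitrogen on an aromatic ring gives a 1.1-fold higher number from compound 2 to compound 3 (0.02 log units; within the scatter), so these two chlorophenyl groups are not told apart here. The large gap to compound 1 therefore follows the group itself: chloro in place of methyl on an aromatic carbon gives an 11-fold lower number from compound 1 to compound 3 (1.06 log units; beyond the scatter). No evidence is available to explain this result.

The compounds shown leave open whether 3-methylphenyl would match 2-methylphenyl or the chlorophenyl groups. They also leave open how a bromo or methoxy group on that aromatic carbon would compare with chloro.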